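This account rests on a few compounds, and the source may have more. Where it says the series, first, only, none or still open, it means among the compounds named here.

Values in a functional assay on A-375 cells (Homo sapiens) for activation, with a stated time of 3 days; on this read-out higher numbers stand for an effect only at larger amounts of compound and lower numbers for an effect already at smaller amounts:
- compound 1 `O=C(Nc1ccc(-c2cscn2)cc1)C1CCCN(Cc2ccc(F)c(F)c2)C1`: 1240 nM
- compound 2 `O=C(Nc1ccc(-c2cscn2)cc1)[C@@H]1CCCN(Cc2ccc(F)c(F)c2)C1`: 4000 nM
- compound 3 `O=C(Nc1ccc(-c2cscn2)cc1)C1CCCN(Cc2ccccc2F)C1`: 7000 nM

In this assay, compound 3 at 7000 nM lies within the usual scatter of compound 2 at 4000 nM, and both numbers are higher than that of compound 1. The next compound, compound 4 `O=C(Nc1ccc(-c2cscn2)cc1)C1CCCN(Cc2ccc(F)cc2)C1`, changes only the fluorinated ring: 4-fluorophenyl in place of 2-fluorophenyl on a saturated chain carbon bound to an amine nitrogen in a ring. This places 4-fluorophenyl in place of 2-fluorophenyl on a saturated chain carbon bound to an amine nitrogen in a ring.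

The stereo step, a 3.2-fold higher number from compound 1 to compound 2 (0.51 log units; beyond the scatter), reflects only (the fact that one of compounds 1 and 2 is drawn with a defined configuration and the other without, at the place where they differ), and it does not bear on this change, as compound 3 and compound 4 are both drawn without a configuration. The relevant measurement is the aryl step, a 5.6-fold higher number from compound 1 to compound 3 (0.75 log units; beyond the scatter), which shows that the number responds to the fluorine pattern on this ring. Part of that modest step is expected to be recovered, giving a modest move towards a lower number. The expected change is a 2.3-fold lower number from compound 3 to compound 4 (0.37 log units; beyond the scatter). For compound 4 the estimated value is 3000 nM, with an expected range of 1100 nM to 8500 nM.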

Compound 4, half-maximal effective concentration: 5000 nM
Compound 4: middle estimate off by 1.7-fold (0.22 log units), on the low side; measured number inside the range.
By their numbers in this assay, from the lowest: compound 1; then compounds 2, 4 and 3 (each within the scatter of the next).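

In this assay, 4-fluorophenyl in place of 2-fluorophenyl leaves the number within the scatter (a 1.4-fold lower number from compound 3 to compound 4 (0.15 log units; within the scatter)), so these two placements of the single fluorine cannot be told apart on a saturated chain carbon bound to an amine nitrogen in a ring. The gap to the difluoro compound remains with the fluorine in this new placement (a 4.0-fold higher number from compound 1 to compound 4 (0.61 log units; beyond the scatter)), so both monofluoro compounds carry higher numbers than compound 1. Nothing in the available evidence bears on the reason for these results.

A 3-fluorophenyl or a plain phenyl group at this place would show whether the lower number of compound 1 needs both fluorines together or mainly the one in the 3-position. Also open, going by these compounds, is how a 4-chlorophenyl or 4-methoxyphenyl group would compare with compound 4.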